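The source may hold more compounds than are shown below. What is called first, only, known or untested is meant among the compounds shown, and "the series" means these compounds.

In a functional assay on NCI-H460 cells (Homo sapiens) for antiproliferative activity, read by MTT assay, with a stated time of 48 h (a higher number here means a weaker inhibitor, a lower number a stronger inhibitor), compound 1 `COc1ccc(Nc2ccc3c(c2)C(O)(Cc2ccccc2)C(=O)N3)cc1` gives > 100000 nM, which is a limit of the assay and not a number. Compound 2 `O=C1Nc2ccc(Nc3ccc(F)cc3)cc2C1(O)Cc1ccccc1` gives 18100 nM. Compound 3 `O=C1Nc2ccc(Nc3ccc(Cl)cc3)cc2C1(O)Cc1ccccc1` gives 20200 nM, which places it level with compound 2 within the scatter, and the chloro-for-fluoro swap amounts to a 1.1-fold higher number from compound 2 to compound 3 (0.05 log units; within the scatter). Replacing methoxy at that same place made a clear difference, with an at least 5.5-fold lower number from compound 1 to compound 2 (0.74 log units; beyond the scatter) and an at least 4.9-fold lower number from compound 1 to compound 3 (0.69 log units; beyond the scatter). Compound 4 `O=C1Nc2ccc(Nc3ccccc3Cl)cc2C1(O)Cc1ccccc1` has 2-chlorophenyl in place of 4-chlorophenyl on a nitrogen on an aromatic ring. Among the compounds with values here, no measured step moves the chloro group, so the evidence is indirect. The closest guide is the swap between compound 2 and compound 3, a 1.1-fold higher number from compound 2 to compound 3 (0.05 log units; within the scatter), though the methoxy steps warn that this ring is not indifferent to change. No shift beyond the scatter is therefore expected in this assay, and the expected change is a 1.1-fold higher number from compound 3 to compound 4 (0.04 log units; within the scatter). For compound 4 the estimate is 22000 nM, with an expected range of 9000 nM to 55000 nM.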

Compound 4, half-maximal inhibitory concentration: 14600 nM
Compound 4: middle estimate off by 1.5-fold (0.18 log units), on the high side, within the range that was stated.
By their numbers in this assay, from the lowest: compounds 4, 2 and 3 (each within the scatter of the next). At a limit, above all of these: compound 1.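

Moving the chloro group from 4-chlorophenyl to 2-chlorophenyl on the nitrogen produces no shift beyond the scatter in this assay, a 1.4-fold lower number from compound 3 to compound 4 (0.14 log units; within the scatter), so at this position a change in where the chloro group sits, and not only a change of halogen, leaves the read-out in place. The 4-fluorophenyl group does not separate from 2-chlorophenyl either, a 1.2-fold lower number from compound 2 to compound 4 (0.09 log units; within the scatter), whereas 4-methoxyphenyl stays clearly apart, an at least 6.8-fold lower number from compound 1 to compound 4 (0.83 log units; beyond the scatter). Compound 1 stands at a limit and not at a number, so that last step gives only a lower bound on the gap: the limit of > 100000 nM in this assay, at which 1 of the 4 values shown sits.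

The compounds shown leave open whether this separation belongs to methoxy alone or would also appear with a hydroxyl, an amine or a carboxylic acid on this ring. They also leave open whether any group here could bring the number below the level shared by compounds 2, 3 and 4.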